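The source may hold more compounds than are shown below. What is called first, only, known or untested is meant among the compounds shown, and "the series" means these compounds.

The measured compounds and their values:

Compound 1 `O=S(=O)(NCCCNCc1ccccc1Cl)c1cc(C(F)(F)F)cc(C(F)(F)F)c1`: 20000 nM
Compound 2 `O=S(=O)(NCCCNCc1ccc(Br)cc1)c1cc(C(F)(F)F)cc(C(F)(F)F)c1`: 2200 nM

Both were tested in a functional assay on HT-29 cells (Homo sapiens) for inhibition, read by MTT assay, with a stated time of 72 h; a higher number here means a weaker inhibitor of growth, a lower number a stronger inhibitor of growth. Within the data shown here, compound 2 stands at the lowest of the two numbers; its only neighbour is compound 1, and the single step recorded between them, a 9.1-fold lower number from compound 1 to compound 2 (0.96 log units; beyond the scatter), goes with 4-bromophenyl in place of 2-chlorophenyl on a saturated chain carbon bound to an amine nitrogen.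

Compound 3 `COc1ccc(CNCCCNS(=O)(=O)c2cc(C(F)(F)F)cc(C(F)(F)F)c2)cc1` is not yet measured. It differs from compound 2 by methoxy in place of bromo on an aromatic carbon, so that 4-bromophenyl becomes 4-methoxyphenyl on the shared core. Among the measured compounds shown here, no measured step exchanges one substituent for another at the same aromatic carbon; the step from compound 1 to compound 2 changes both the halogen and where it sits, so it bears on this change only loosely. For the measured compounds named here, with a modest step the only precedent, the expected change in this assay from compound 2 to compound 3 is small, most likely toward a somewhat higher number, and could fall within the scatter: a 1.6-fold higher number from compound 2 to compound 3 (0.20 log units; within the scatter). Compound 3 is therefore estimated at 3500 nM, with a range from 1000 nM to 12000 nM.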

Compound 3, concentration for 50% growth inhibition: 2900 nM
The estimate for compound 3 lay 1.2-fold (0.08 log units) above the measured number; measured number inside the range.
By their numbers in this assay, from the lowest: compounds 2 and 3 (each within the scatter of the next); then compound 1.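

In this assay the exchange on this aromatic carbon, para to a large group, gives a 1.3-fold higher number from compound 2 to compound 3 (0.12 log units; within the scatter) and so does not separate bromo, with 1 heavy atom and no hydrogen-bond acceptor, from methoxy, with 2 heavy atoms and 1 hydrogen-bond acceptor. The step of a 6.9-fold lower number from compound 1 to compound 3 (0.84 log units; beyond the scatter) shows that 4-methoxyphenyl, like 4-bromophenyl, stands clear of 2-chlorophenyl, so the distance from compound 1 does not rest on bromo alone. No evidence on the cause of either result is at hand.

The step from compound 1 changes both the group and its place on the ring, so the compounds shown leave open which of the two goes with the lower number, a question that 4-chlorophenyl or 2-methoxyphenyl on the shared core would address. They also leave open whether the tolerance seen here extends to very different groups on the same carbon, such as an amine or a carboxylic acid.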